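The source may hold more compounds than are shown below. What is called first, only, known or untested is meant among the compounds shown, and "the series" means these compounds.

Compound 1 `c1ccc(-c2nc[nH]n2)c(NCC2=NCCN2)c1` gives 3.98 nM in an in vitro functional assay on cells (Fibroblast) for agonist activity at Alpha-1D adrenergic receptor (Homo sapiens); a lower number here means that less compound is needed, a higher number that more compound is needed for the effect. Compound 2 `Cn1ncnc1-c1ccccc1NCC1=NCCN1` gives 63.1 nM in this assay, and the change from its parent is a 16-fold higher number from compound 1 to compound 2 (1.20 log units; beyond the scatter). For compound 3 `Cn1nccc1-c1ccccc1NCC1=NCCN1` only a limit is known in this assay, < 100000 nM. Consequently the steps a step that the limit leaves unreadable from compound 1 to compound 3 and a step that the limit leaves unreadable from compound 2 to compound 3 cannot be sized. Compound 4 `CC(C)n1nccc1-c1ccccc1NCC1=NCCN1` differs from compound 3 by isopropyl in place of methyl on an aromatic nitrogen. Going by the values given here, no measured step covers this change; the one readable step, a 16-fold higher number from compound 1 to compound 2 (1.20 log units; beyond the scatter), concerns a different group. Compound 3 sits at the limit of < 100000 nM in this assay, at which 1 of the 3 values shown sits, and offers no number to build from. Compound 4 is therefore expected, with little confidence, to show a step that the limit leaves unreadable from compound 3 to compound 4, estimated near 30000 nM within a range from 3000 nM to 100000 nM, and this assay may again report only a limit.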

Compound 4, half-maximal effective concentration: < 100000 nM
Compound 4: only a limit was reported (the forecaster's own chance of this, stated with the estimate: 60%); the middle value lies beyond the limit too.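

Going by these compounds alone, compound 3 and compound 4 both stand only as limits in this assay, so no step between them can be read. Still open, on these data alone, is whether isopropyl in place of methyl on an aromatic nitrogen changes the read-out at all.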